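Swapping a vinyl for an amide chain on the shared core

This account rests on a few compounds, and the source may have more. Where it says the series, first, only, none or still open, it means among the compounds named here.

Compound 1 `C=Cn1c2ccc([N+](=O)[O-])cc2c(=O)n1Cc1ccccc1` is the starting point. In an ADME assay on L929 cells (Mus musculus) for cytotoxicity, read by resazurin assay, with a stated time of 48 h (a higher number here means that more compound is tolerated, a lower number that less compound is tolerated), compound 1 gives 160000 nM, the highest of the three numbers measured, so it is the best tolerated of the three. Two close relatives show what happens when the vinyl on the aromatic nitrogen is replaced by a longer chain. Compound 2 `O=c1c2cc([N+](=O)[O-])ccc2n(CCCBr)n1Cc1ccccc1` gives 25200 nM, and the change a 6.3-fold lower number from compound 1 to compound 2 (0.80 log units; beyond the scatter). Compound 3 `CCOC(=O)CCCn1c2ccc([N+](=O)[O-])cc2c(=O)n1Cc1ccccc1` gives 78100 nM, and the change a 2.0-fold lower number from compound 1 to compound 3 (0.31 log units; beyond the scatter). Between these two chains, a 3.1-fold higher number from compound 2 to compound 3 (0.49 log units; beyond the scatter).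

Compound 4 `CN(C)C(=O)CCCn1c2ccc([N+](=O)[O-])cc2c(=O)n1Cc1ccccc1` has not yet been tested. It differs from compound 1 in one place: 3-(dimethylcarbamoyl)propyl in place of vinyl on an aromatic nitrogen. The chain entering here resembles the ester chain of compound 3 more than the bromo chain of compound 2, so the step from compound 1 to compound 3 is the closer guide, and a modest drop is expected; the step is estimated as a 1.6-fold lower number from compound 1 to compound 4 (0.20 log units; within the scatter). Compound 4 is therefore expected to give about 100000 nM, with a likely range from 50000 nM to 200000 nM.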

Compound 4, concentration lethal to 50% of the cells: > 256000 nM
Compound 4 ended at the assay's limit; the forecaster's own chance of this, stated with the estimate: 15%; middle value at least 2.5-fold (0.40 log units) away from the limit.
By their numbers in this assay, from the lowest: compound 2; then compound 3; then compound 1. At a limit, above all of these: compound 4.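

In this assay compound 4 gives > 256000 nM, which is a limit of the assay and not a number: the limit of > 256000 nM in this assay, at which 1 of the 4 values shown sits.

Both earlier chains on this aromatic nitrogen lowered the number relative to vinyl, but the 3-(dimethylcarbamoyl)propyl chain does not, with an at least 1.6-fold higher number from compound 1 to compound 4 (0.20 log units; that floor lies within the scatter), so a longer chain at this position does not by itself mean a lower number. What stands at the end of the chain makes a clear difference: dimethylamino in place of ethoxy on the carbonyl carbon gives an at least 3.2-fold higher number from compound 3 to compound 4 (0.51 log units; beyond the scatter), and dimethylcarbamoyl in place of bromo gives an at least 10-fold higher number from compound 2 to compound 4 (1.00 log units; beyond the scatter).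

On these data alone, how far the true value of compound 4 lies past the limit stays open. So does whether a carboxylic acid or an amine at the end of the same chain, or a longer chain carrying the same amide, would behave like compound 4.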